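This account rests on a few compounds, and the source may have more. Where it says the series, first, only, none or still open, it means among the compounds named here.

In a functional assay on MCF7 cells (Homo sapiens) for antiproliferative activity (on this read-out higher numbers stand for weaker inhibition and lower numbers for stronger inhibition), compound 1 (`CC(C)=CCc1cc(C(=O)Nc2cc3ccc(OCCC4CCCCN4)c(C)c3oc2=O)ccc1O`) gives 710 nM and compound 2 (`CC(C)=CCc1cc(C(=O)Nc2cc3ccc(OCC4CCN(C)C4)c(C)c3oc2=O)ccc1O`) gives 1550 nM, so compound 2 holds the higher of the two numbers. For the measured compounds named here, the only measured step, a 2.2-fold higher number from compound 1 to compound 2 (0.34 log units; beyond the scatter), is modest and concerns the same place in the structure. Compound 3 (`CCNCCCOc1ccc2cc(NC(=O)c3ccc(O)c(CC=C(C)C)c3)c(=O)oc2c1C`) differs from compound 2 there: 2-(ethylamino)ethyl in place of 1-methylpyrrolidin-3-yl on a saturated chain carbon bound to an oxygen on an aromatic ring. With that single step as a guide, only a modest move in this assay is expected, towards the number of compound 1 at 710 nM. The expected step is a 1.6-fold lower number from compound 2 to compound 3 (0.19 log units; within the scatter). For compound 3 the estimated value is 1000 nM, with an expected range of 400 nM to 2500 nM.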

Compound 3, half-maximal inhibitory concentration: 980 nM
Estimate against measurement, compound 3: 1.0-fold (0.01 log units) above, and the stated range covers the measured number.
By their numbers in this assay, from the lowest: compounds 1, 3 and 2 (each within the scatter of the next, the first and the last beyond it).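

In this assay, the open 2-(ethylamino)ethyl group, which has no ring, stands within the scatter of both ring-bearing compounds: the change reads a 1.6-fold lower number from compound 2 to compound 3 (0.20 log units; within the scatter) and a 1.4-fold higher number from compound 1 to compound 3 (0.14 log units; within the scatter). A ring at this position is therefore not what separates these three numbers, and compound 3 keeps an open chain without leaving the range of the other two. No measurement here accounts for these numbers. The compounds shown leave open how a morpholine ring or a longer chain would read at this position, and whether a chain ending in a hydroxyl group, with no amine, would fall in the same range.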